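A few compounds are considered here, and "the series" means these few. Any claim that something is new, unique, unknown or untested is made for them only; others in the source may bear on it.

Measured compounds:
- Compound 1 `C[C@@H]1O[C@@H](N2C(=O)/C(=C3\Nc4ccccc4C3=O)c3ccccc32)[C@H](O)[C@H](O)[C@H]1O`: > 25000 nM
- Compound 2 `C[C@@H]1O[C@H](N2C(=O)/C(=C3\Nc4ccccc4\C3=N/O)c3ccccc32)[C@H](O)[C@H](O)[C@H]1O`: "not determined" (no result reported)
- Compound 3 `C[C@@H]1O[C@H](N2C(=O)/C(=C3\Nc4ccc(Cl)cc4C3=O)c3ccccc32)[C@H](O)[C@H](O)[C@H]1O`: "not determined" (no result reported)

The three compounds share a sugar joined to a colored bis-indole core and were tested in a functional assay on A-427 cells (Homo sapiens) for antiproliferative activity, read by crystal violet staining, with a stated time of 96 h; a lower number here means a stronger inhibitor, a higher number a weaker inhibitor. Compound 1 gives only a limit, > 25000 nM, and not a number. For compound 2 the entry in this assay is "not determined" (no result reported). Compound 3 likewise has no single number in this assay, its entry being "not determined" (no result reported); of the other two values shown, one sits at the limit of > 25000 nM in this assay, at which 1 of the 3 values shown sits, and one is an entry without a number. Among the measured compounds shown here, compound 3 therefore stands nowhere on a scale; nothing among the measured compounds places it.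

Compound 4 `C[C@@H]1O[C@H](N2C(=O)/C(=C3\Nc4ccccc4C3=O)c3ccccc32)[C@H](O)[C@H](O)[C@H]1O` differs from compound 3 by hydrogen in place of chloro on an aromatic carbon. Since no step between measured compounds is shown, there is no measured size to lean on. For the measured compounds named here, the only number in view is the limit of compound 1 in this assay, and that points to weak inhibition; the exchange of chloro for hydrogen is expected to shift the value by no more than the usual scatter, in no set direction. Compound 4 is therefore estimated at 20000 nM in this assay, within 5000 nM to 60000 nM, and most likely reported as a limit.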

Compound 4, half-maximal inhibitory concentration: > 12500 nM
Compound 4: no number, only a limit (the forecaster's own chance of this, stated with the estimate: 65%); the middle value does not contradict the limit.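

In this assay compound 4, like compound 1, gives only a limit and not a number, so no step can be read between compound 1 and compound 4, which differ only in configuration as drawn. The compounds shown leave open whether that stereocentre, or the exchange of chloro for hydrogen between compound 3 and compound 4, alters the result in this assay.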